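This account rests on a few compounds, and the source may have more. Where it says the series, first, only, none or still open, it means among the compounds named here.

For the measured compounds named here, in a functional assay on EC9706 cells (Homo sapiens) for cytotoxicity, read by MTT assay, with a stated time of 72 h (a lower number here means a stronger inhibitor, a higher number a weaker inhibitor), compound 3 (`O=C(CSC(=S)N[C@H]1CCOC1=O)Nc1ccc(C(=O)/C=C/c2ccc(Cl)cc2)cc1`) stands at 38900 nM and holds the highest of the three numbers measured so far. Compound 4 (`O=C(CSC(=S)N[C@H]1CCOC1=O)Nc1ccc(C(=O)/C=C/c2cccc(Cl)c2)cc1`) has the same atoms joined differently, with 3-chlorophenyl in place of 4-chlorophenyl on a double-bonded chain carbon (3-chlorophenyl in place of 4-chlorophenyl on a double-bonded chain carbon bound to a double-bonded chain carbon). Going by the values given here, the one measured step, a 4.7-fold higher number from compound 1 to compound 3 (0.67 log units; beyond the scatter), replaces a chlorine atom on a saturated chain carbon and leaves the 4-chlorophenyl untouched, so it does not bear directly on this change. Among the compounds with values here, no measured pair isolates the move of the chlorine. The nearest evidence is compound 1 (`O=C(CCl)Nc1ccc(C(=O)/C=C/c2ccc(Cl)cc2)cc1`) at 8340 nM and compound 2 (`COc1cccc(/C=C/C(=O)c2ccc(NC(=O)CCl)cc2)c1`) at 5970 nM in this assay, whose values lie within the scatter of each other although their aryl groups differ. On that slender basis, no step beyond the scatter is expected in this assay, and the estimated step is a 1.2-fold lower number from compound 3 to compound 4 (0.07 log units; within the scatter). For compound 4 the expected value is 33000 nM, with an estimated range from 13000 nM to 80000 nM.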

Compound 4, half-maximal inhibitory concentration: 32500 nM
Compound 4: the middle estimate sits 1.0-fold (0.01 log units) above what was measured; measured number inside the range.
By their numbers in this assay, from the lowest: compounds 2 and 1 (each within the scatter of the next); then compounds 4 and 3 (each within the scatter of the next).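

In this assay, for the compounds shown here, the exchange of 4-chlorophenyl for 3-chlorophenyl on a double-bonded chain carbon bound to a double-bonded chain carbon gives a 1.2-fold lower number from compound 3 to compound 4 (0.08 log units; within the scatter), the first measured pair that isolates the place of the chlorine on this phenyl ring. With the shared core held constant, the two placements cannot be told apart in this assay, so the high number of compound 3 does not depend on which of these two chlorophenyl groups is present. Nothing available explains this outcome.

Going by these compounds, it remains open whether the two chlorophenyl groups would also match when a chlorine atom stands on the saturated chain carbon in place of the larger group of compound 3. Also open, on these data alone, is how an amine, a nitrile or a carboxylic acid on this phenyl ring would compare with the chlorine.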